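The source may hold more compounds than are shown below. What is called first, only, known or untested is meant among the compounds shown, and "the series" means these compounds.

Measured so far: compound 1 `C=C1[C@H](C)CCC[C@]1(C)CC/C(C)=C/CC1=C(O)C(=O)C=C(N[C@@H](C(=O)O)C(C)C)C1=O` gives 3.4 ug/mL in an ADME assay on L1210 cells (Mus musculus) for cytotoxicity, with a stated time of 48 h; on this read-out lower numbers stand for stronger inhibition and higher numbers for weaker inhibition; compound 2 `CC1=CCC[C@H]2[C@](C)(CC3=C(O)C(=O)C=C(N[C@@H](CO)C(=O)O)C3=O)[C@@H](C)CC[C@]12C` gives 3.8 ug/mL; compound 3 `CC1=CCC[C@](C)(CC/C(C)=C/CC2=C(O)C(=O)C=C(N[C@@H](C(=O)O)C(C)C)C2=O)[C@@H]1C` gives 3 ug/mL.

Compound 1 stands second highest of the three numbers, with compound 2 and compound 3 each within the scatter of it. Compound 4 `C=C1[C@H](C)CCC[C@]1(C)CC/C(C)=C/CC1=C(O)C(=O)C=C(NCC(=O)O)C1=O` is not yet measured; it differs from compound 1 by hydrogen in place of isopropyl on a saturated chain carbon bound to an amine nitrogen and a carbonyl carbon. Within the data shown here, no measured step touches this position: the one step known, a 1.1-fold lower number from compound 1 to compound 3 (0.05 log units; within the scatter), swaps the six-membered carbon ring and stays within the scatter, while compound 2 differs from compound 1 in two places and shows a value within the scatter of it. On this thin evidence the step of a 1.0-fold higher number from compound 1 to compound 4 (0.01 log units; within the scatter) is expected to stay within the scatter. Compound 4 is therefore estimated at 3.5 ug/mL, in a range of 1.7 ug/mL to 7.5 ug/mL.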

Compound 4, half-maximal inhibitory concentration: 4 ug/mL
Compound 4: middle estimate off by 1.1-fold (0.06 log units), on the low side; measured number inside the range.
By their numbers in this assay, from the lowest: compounds 3, 1, 2 and 4 (each within the scatter of the next).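

In this assay, hydrogen in place of isopropyl on a saturated chain carbon bound to an amine nitrogen and a carbonyl carbon gives a 1.2-fold higher number from compound 1 to compound 4 (0.07 log units; within the scatter). Among these compounds, this is the first measured step at this position, and it shows that the isopropyl can be lost without the number leaving the scatter. Nothing measured here offers an explanation for this result. The compounds shown leave open whether a phenyl ring or an aminobutyl chain on this carbon would also stay within the scatter.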